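The source may report more compounds than this note shows. Statements on the series, on what has been measured and on what is new or still open speak of the compounds shown alone.

Measured compounds:
Compound 1, `O=c1[nH]nc2n(c1=O)CCN2c1ccccc1`: 0%
Compound 2, `COc1ccc(N2CCN/C2=N\N)cc1`: 17%
Compound 3, `COc1ccccc1N1CCn2c1n[nH]c(=O)c2=O`: 1%

In a functional assay on T47D cells (Homo sapiens) for cytotoxicity, with a stated time of 72 h, tested at 10 ug/mL (on this read-out higher numbers stand for a stronger effect at the one concentration tested and lower numbers for a weaker effect), compound 2 stands highest of the three, with compound 3 and compound 1 both lying beyond the scatter below it. Compound 2 and compound 3 carry different cores; the difference between the two cores is not broken down here.

Within the core of compound 3, the change hydrogen in place of methoxy on an aromatic carbon gives the step of a number 1 percentage points lower from compound 3 to compound 1 (within the scatter), so the methoxy makes no difference that can be told from scatter in that pair.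

Compound 4, `N/N=C1\NCCN1c1ccccc1`, is not yet measured in this assay. It derives from compound 2 by hydrogen in place of methoxy on an aromatic carbon. Among the measured compounds shown here, this is the same kind of change as the one from compound 3 to compound 1, though the surroundings differ: in compound 2 the methoxy sits para to a group of 7 heavy atoms, whereas in compound 3 it sits ortho to a large group.

Resting on the step of a number 1 percentage points lower from compound 3 to compound 1 (within the scatter) within the other core, the step from compound 2 to compound 4 is expected to be small, about a number 2 percentage points lower from compound 2 to compound 4 (within the scatter). Compound 4 is therefore estimated at 15%, between 4% and 28%.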

Compound 4, a percentage reported as inhibition, at one concentration (the size of the read-out at that concentration, not a potency): 0%
Compound 4: the middle estimate sits 15 percentage points above what was measured, and the stated range ends above it.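

In this assay, hydrogen in place of methoxy on the core of compound 2 gives a number 17 percentage points lower from compound 2 to compound 4 (beyond the scatter), so on this core the methoxy separates the two compounds at the one concentration tested. The change therefore does not carry over with the same size from one core to the other in this series: the same change on two cores in this assay, a number 1 percentage points lower (within the scatter) from compound 3 to compound 1 and a number 17 percentage points lower (beyond the scatter) from compound 2 to compound 4, 16 percentage points apart, beyond the scatter of two such steps

This rests on a single pair per core, and the methoxy does not stand in the same place on the ring in the two pairs, so the data cannot separate the effect of the core from that of the position, and they give no reason for the gap.

The compounds shown carry only hydrogen or methoxy on the aromatic ring, which leaves open whether the step on the core of compound 2 is particular to methoxy. An ethoxy, a hydroxyl or a chlorine para to a group of 7 heavy atoms would bear on that, and a methoxy in that same place on the core of compound 1 would bear on the role of the core.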